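The source may report more compounds than this note shows. Statements on the series, on what has been measured and on what is new or still open speak of the compounds shown alone.

Working notes on the series. Compound 3 `O=C(CCCCC1CCSS1)NCc1cn(CCCCCOc2ccc3cc(-c4ccccc4)c(=O)oc3c2)nn1` stands lowest of the three measured numbers in a functional assay on PC-12 cells (Rattus norvegicus) for cytotoxicity, read by MTT assay, with stated times of 3 h and 2 h, tested at 50 uM; a higher number here means a stronger effect of the compound at the concentration tested, a lower number a weaker effect: compound 3 gives 17.7%. Its nearest neighbour is compound 2 `CC(=O)c1cc2ccc(OCCCCCn3cc(CNC(=O)CCCCC4CCSS4)nn3)cc2oc1=O`, which gives 18.2%; the step of a number 0.5 percentage points lower from compound 2 to compound 3 (within the scatter) is within the scatter. Furthest away is compound 1 `O=C(CCCCC1CCSS1)NCc1cn(CCCCCOc2ccc3ccc(=O)oc3c2)nn1`, which gives 84.9%; the steps of a number 66.7 percentage points lower from compound 1 to compound 2 (beyond the scatter) and a number 67.2 percentage points lower from compound 1 to compound 3 (beyond the scatter) are both large.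

Compound 4 `COc1ccc(-c2cc3ccc(OCCCCCn4cc(CNC(=O)CCCCC5CCSS5)nn4)cc3oc2=O)cc1` is the next member. It differs from compound 3 by methoxy in place of hydrogen on an aromatic carbon. Among the compounds with values here, no measured step concerns this exact change. The two large steps both replace hydrogen on the shared core with acetyl or phenyl, whereas the change here sits on the phenyl already present. Within the data shown here, the only measured step that touches that phenyl, a number 0.5 percentage points lower from compound 2 to compound 3 (within the scatter), was within the scatter. On this basis, no step beyond the scatter in this assay is expected in either direction.

Compound 4 is therefore estimated to give 20%, within 8% to 40%. The expected step of a number 2.3 percentage points higher from compound 3 to compound 4 (within the scatter) is estimated to lie within the scatter.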

Compound 4, a percentage reported as activity, at one concentration (the size of the read-out at that concentration, not a potency): 52.8%
For compound 4 the middle estimate is 32.8 percentage points below the measured one; measured number above the stated range.
By their numbers in this assay, from the lowest: compounds 3 and 2 (each within the scatter of the next); then compound 4; then compound 1.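

In this assay the phenyl on the shared core proves sensitive to substitution: methoxy in place of hydrogen, para to a large group, gives a number 35.1 percentage points higher from compound 3 to compound 4 (beyond the scatter) and so goes beyond the scatter, unlike the earlier exchange of acetyl for phenyl. The 4-methoxyphenyl group also separates from acetyl, with a number 34.6 percentage points higher from compound 2 to compound 4 (beyond the scatter) as the step, yet it does not reach the level of the unsubstituted core, with a number 32.1 percentage points lower from compound 1 to compound 4 (beyond the scatter) as the step, so a group at this core position need not bring the full drop seen earlier. No evidence bearing on the origin of this rise is available.

On these data alone, it remains open whether the rise is specific to methoxy or would also follow from another group at the same place. A hydroxyl, an amine or a longer alkoxy chain on that phenyl would separate these readings.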